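The source may hold more compounds than are shown below. What is called first, only, known or untested is meant among the compounds shown, and "the series" means these compounds.

Working notes on the series. Compound 2 `COc1ccc(-c2cc(/C=C/C(=O)c3ccc(N)cc3)[nH]n2)cc1OC` in a functional assay on SN12C cells (Homo sapiens) for inhibition, read by sulforhodamine B assay, with a stated time of 48 h (on this read-out lower numbers stand for stronger inhibition of growth and higher numbers for weaker inhibition of growth), gives 3530 nM. Compound 1 `COc1ccc(-c2cc(/C=C/C(=O)c3ccc(N)cc3)[nH]n2)cc1` differs from it by hydrogen in place of methoxy on an aromatic carbon; in this assay compound 1 gives 1890 nM, the step being a 1.9-fold lower number from compound 2 to compound 1 (0.27 log units; within the scatter). Compound 3 `COc1cc(C(=O)/C=C/c2cc(-c3cc(OC)c(OC)c(OC)c3)n[nH]2)cc(OC)c1OC` carries another core; the difference between the two cores is not broken down here. In this assay compound 3 gives 1470 nM, within the scatter of compound 1 and beyond the scatter from compound 2. Compound 4 `COc1ccc(-c2cc(/C=C/C(=O)c3cc(OC)c(OC)c(OC)c3)[nH]n2)cc1OC` is not yet measured. It differs from compound 3 by hydrogen in place of methoxy on an aromatic carbon, the same kind of change as that from compound 2 to compound 1, though here the place is also meta to a methoxy group (2 heavy atoms). Among the compounds with values here, the only precedent is a 1.9-fold lower number from compound 2 to compound 1 (0.27 log units; within the scatter), which is within the scatter. On that footing the expected step is a 1.5-fold lower number from compound 3 to compound 4 (0.17 log units; within the scatter). Compound 4 is therefore estimated at 1000 nM, between 450 nM and 2500 nM.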

Compound 4, concentration for 50% growth inhibition: 1770 nM
The estimate for compound 4 lay 1.8-fold (0.25 log units) below the measured number; measured number inside the range.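

In this assay, hydrogen in place of methoxy gives a 1.2-fold higher number from compound 3 to compound 4 (0.08 log units; within the scatter), so on this second core too the change leaves the number within the scatter. Set beside the earlier step, the two do not separate: the same change on two cores in this assay, a 1.9-fold lower number (0.27 log units; within the scatter) from compound 2 to compound 1 and a 1.2-fold higher number (0.08 log units; within the scatter) from compound 3 to compound 4, 2.2-fold (0.35 log units) apart, within the scatter of two such steps. Within the data shown here, this shows that the change carries across these two cores without a detectable difference, but with only two pairs, neither step beyond the scatter, it does not show that the change has a real effect or that the effect is the same on both cores.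

The compounds shown leave open whether a hydroxyl, a fluorine or a longer ethoxy chain at this place would move the number beyond the scatter on either core. Also open, as far as these compounds go, is how the change behaves on any further core.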